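Turning One Stereocentre of the Shared Core

The compounds below may be only part of what the source reports. "The series", "measured", "known", "first", "only" and "open" are said of these compounds alone.

Of the compounds shown here, three built on one shared core have been measured in a functional assay for inhibition, tested at 100 uM; a lower number here means less inhibition, a higher number more inhibition at the concentration tested (going by the name of the read-out). Compound 1 `CCSC1=N[C@@H](C(=O)OC)[C@@H]2C(=O)N(c3ccccc3)C(=O)[C@H]12` gives 91%. Compound 2 `CCCCSC1=N[C@@H](C(=O)OC)[C@@H]2C(=O)N(c3ccccc3)C(=O)[C@H]12`, which carries a longer chain on the sulfur, gives 82%, and a number 9 percentage points lower from compound 1 to compound 2 (within the scatter). Compound 3 `CCCSC1=N[C@H](C(=O)OC)[C@@H]2C(=O)N(c3ccccc3)C(=O)[C@H]12` gives 86% in this assay; its number lies between those of the other two, and both gaps are within the scatter, so the three cannot be told apart on these readings.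

Compound 4 `CCCSC1=N[C@@H](C(=O)OC)[C@@H]2C(=O)N(c3ccccc3)C(=O)[C@H]12` has the same atoms and bonds as compound 3; (the two compounds have the same atoms and bonds and differ only in configuration as drawn: 1 of 3 stereo elements differ; a stereocentre at a saturated ring carbon is drawn S in compound 3 and R in compound 4). Within the data shown here, no measured step touches a stereocentre: the one measured step changes only a chain on the sulfur and stays within the scatter, so it offers no guide to how the configuration of the core matters here. With nothing to set a direction, the expectation for compound 4 is a number near that of compound 3, a number 6 percentage points lower from compound 3 to compound 4 (within the scatter), but with a wide range to allow for an unmeasured kind of change. Compound 4 is therefore estimated at 80%, between 45% and 95%.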

Compound 4, a percentage reported as inhibition, at one concentration (the size of the read-out at that concentration, not a potency): 86%
Beside the measured number, compound 4's estimate is 6 percentage points below it, within the range that was stated.
By their numbers in this assay, from the lowest: compounds 2, 3, 4 and 1 (each within the scatter of the next).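

In this assay, among these compounds, the stereocentre at a saturated ring carbon, drawn S in compound 3 and R in compound 4, gives no change at the digits printed from compound 3 to compound 4 (within the scatter), the first measured step that touches the configuration of the shared core. Compound 4 also links to the other two compounds through the chain on the sulfur: hydrogen in place of methyl three bonds along the chain gives a number 4 percentage points higher from compound 2 to compound 4 (within the scatter), and methyl in place of hydrogen two bonds along gives a number 5 percentage points lower from compound 1 to compound 4 (within the scatter), so neither chain step can be told from scatter. The first comparison isolates this one stereocentre: the fact that compounds 3 and 4 differ only in the configuration as drawn

All these readings come from one tested concentration, which leaves open whether the two configurations would separate at a lower one. Also open, on these data alone, is whether an amine or a carboxylic acid on the shared core, or a longer chain on the sulfur, would make this configuration count.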